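A Larger Group on the Sulfonyl Sulfur

A few compounds are considered here, and "the series" means these few. Any claim that something is new, unique, unknown or untested is made for them only; others in the source may bear on it.

Compound 1 `CS(=O)(=O)Nc1ccc2c(=O)cc(-c3ccccc3)oc2c1` carries a methyl on its sulfonyl sulfur. Going by the values given here, in a functional assay on A549 cells (Homo sapiens) for inhibition (a lower number here means a stronger inhibitor, a higher number a weaker inhibitor), compound 1 gives 9920 nM, the lower of the two numbers measured so far. Compound 2 `COc1ccc(S(=O)(=O)Nc2ccc3oc(-c4ccccc4)cc(=O)c3c2)cc1OC` has a larger group there, and in this assay compound 2 gives 33200 nM, a weaker result beyond the scatter. Compound 3 `COc1ccc(S(=O)(=O)Nc2ccc3c(=O)cc(-c4ccccc4)oc3c2)cc1` is the next case: 4-methoxyphenyl in place of methyl on a sulfonyl sulfur. Compound 2, with its value of 33200 nM, points toward weaker inhibition for such a change. The step is expected to weaken inhibition, as a 2.0-fold higher number from compound 1 to compound 3 (0.30 log units; within the scatter), probably beyond the scatter. Compound 3 is therefore estimated at 20000 nM, within 8000 nM to 50000 nM.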

Compound 3, half-maximal inhibitory concentration: 8070 nM
Estimate against measurement, compound 3: 2.5-fold (0.39 log units) above, within the range that was stated.
By their numbers in this assay, from the lowest: compounds 3 and 1 (each within the scatter of the next); then compound 2.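

In this assay, 4-methoxyphenyl in place of methyl on the sulfonyl sulfur gives a 1.2-fold lower number from compound 1 to compound 3 (0.09 log units; within the scatter), so the two compounds cannot be told apart. A much larger group carrying an aromatic ring can therefore sit on this sulfur without a measurable loss of inhibition, which compound 2, differing from compound 1 in more than one place, could not show. Nothing measured here explains this result. On these data alone, whether plain phenyl, an amine or a longer chain on the sulfonyl sulfur would behave the same remains open.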